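Amide Variation on a Shared Core: From Azetidine to Dimethylamine

A few compounds are considered here, and "the series" means these few. Any claim that something is new, unique, unknown or untested is made for them only; others in the source may bear on it.

Measured compounds in a functional assay on BT-474 cells (Homo sapiens) for antiproliferative activity, read by sulforhodamine B assay, with a stated time of 4 days; on this read-out lower numbers stand for stronger inhibition of growth and higher numbers for weaker inhibition of growth:
compound 1, `COc1cc(Cl)c(-c2nc(SCC(=O)NC(C)C)nc3[nH]cc(C#N)c23)cc1O`, 161 nM
compound 2, `COc1cc(Cl)c(-c2nc(SCC(=O)NC(C)(C)C)nc3[nH]cc(C#N)c23)cc1O`, 128 nM
compound 3, `COc1cc(Cl)c(-c2nc(SCC(=O)N3CCC3)nc3[nH]cc(C#N)c23)cc1O`, 21 nM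

Compound 3 gives the lowest number of the three, and its gaps to the others are beyond the scatter: a 7.7-fold lower number from compound 1 to compound 3 (0.88 log units; beyond the scatter) and a 6.1-fold lower number from compound 2 to compound 3 (0.78 log units; beyond the scatter). Compound 1 and compound 2 differ from each other only within the scatter: a 1.3-fold lower number from compound 1 to compound 2 (0.10 log units; within the scatter).

Compound 4, `COc1cc(Cl)c(-c2nc(SCC(=O)N(C)C)nc3[nH]cc(C#N)c23)cc1O`, is not yet measured. It differs from compound 3 as follows: dimethylamino in place of azetidin-1-yl on a carbonyl carbon. Going by the values given here, no measured step covers this exact exchange; the two steps into compound 3 show only that the azetidin-1-yl amide gave lower numbers than the two secondary amides. Compound 4 is therefore expected to stay near compound 3, perhaps somewhat higher, as a 1.9-fold higher number from compound 3 to compound 4 (0.28 log units; within the scatter) in this assay; the estimate for compound 4 is 40 nM, with a range from 15 nM to 120 nM.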

Compound 4, concentration for 50% growth inhibition: 20 nM
The estimate for compound 4 lay 2.0-fold (0.30 log units) above the measured number; the range from low to high includes it.
By their numbers in this assay, from the lowest: compounds 4 and 3 (each within the scatter of the next); then compounds 2 and 1 (each within the scatter of the next).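

In this assay, the ring of azetidin-1-yl is not needed on this carbonyl carbon: with dimethylamino in its place, the numbers stay together (a 1.1-fold lower number from compound 3 to compound 4 (0.02 log units; within the scatter)). An open-chain group without the amide hydrogen also stands clearly apart from the two secondary amides (a 6.4-fold lower number from compound 2 to compound 4 (0.81 log units; beyond the scatter); an 8.1-fold lower number from compound 1 to compound 4 (0.91 log units; beyond the scatter)). Nothing measured here explains this difference.

As far as these compounds go, it remains open whether methylamino, which keeps the amide hydrogen, would group with compound 1 and compound 2. From the compounds shown here alone, it is equally open whether pyrrolidin-1-yl or morpholin-4-yl would stay with compound 3 and compound 4.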